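This account rests on a few compounds, and the source may have more. Where it says the series, first, only, none or still open, it means among the compounds named here.

Measured compounds in this series:

- compound 1, `COc1cc(C2=NN(C(C)=O)C(c3cc(Cl)cc(Cl)c3)O2)cc(OC)c1OC`: 52.7%
- compound 2, `COc1cc(/C=N/NC(=O)c2cc(OC)c(OC)c(OC)c2)cc(OC)c1OC`: 8.5%

In a functional assay on PC-3 cells (Homo sapiens) for antiproliferative activity, read by MTT assay, tested at 1 uM (on this read-out lower numbers stand for a weaker effect and higher numbers for a stronger effect at the one concentration tested), compound 1 gives 52.7%, the highest of the two numbers recorded. Going by the values given here, compound 2 gives 8.5% in this assay, a gap to compound 1 that lies beyond the usual scatter; since the two structures differ in more than one place, the pair shows only that the numbers lie far apart and nothing about any single change.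

Compound 3, `COc1cc(C2=NN(C(C)=O)C(c3ccccc3F)O2)cc(OC)c1OC`, is not yet measured. It differs from compound 1 in one place: 2-fluorophenyl in place of 3,5-dichlorophenyl on a saturated ring carbon. Among the compounds with values here, no measured pair isolates a change of this kind, so the step has no measured precedent here. Given that compound 1 carries the larger, twice-halogenated ring and stands at 52.7%, a downward step of moderate size is expected for compound 3, possibly reaching beyond the scatter but not to the level of compound 2. The expected step is a number 17.7 percentage points lower from compound 1 to compound 3 (beyond the scatter). Compound 3 is accordingly estimated at 35%, with a range from 15% to 55%.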

Compound 3, a percentage reported as inhibition, at one concentration (the size of the read-out at that concentration, not a potency): 13.5%
Estimate against measurement, compound 3: 21.5 percentage points above, and the stated range ends above it.
By their numbers in this assay, from the lowest: compounds 2 and 3 (each within the scatter of the next); then compound 1.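

In this assay, going by these compounds alone, the change from 3,5-dichlorophenyl to 2-fluorophenyl on the saturated ring carbon gives the first single-place step (a number 39.2 percentage points lower from compound 1 to compound 3 (beyond the scatter)), and that step is large. This position is therefore not indifferent: with the rest of the core of compound 1 unchanged, the exchange of one halogenated phenyl for another is enough to move the read-out at the one concentration tested well beyond the scatter. Nothing available here bears on why the step arises.

The single step changes the halogen, the number of halogens and their place on the phenyl together, so the compounds shown cannot separate these three contributions or say which of them carries the step. Also open, from the compounds shown here alone, is where an unsubstituted phenyl, a 2-chlorophenyl, a 3,5-difluorophenyl or a phenyl carrying an amine on this carbon would fall relative to compound 1 and compound 3, and whether the step would keep its size in this assay if the acetyl group on the neighbouring ring atom were replaced by a longer acyl chain.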